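Ethoxy for Methoxy at the Edge of Detection

The source may hold more compounds than are shown below. What is called first, only, known or untested is meant among the compounds shown, and "the series" means these compounds.

Measured compounds:
compound 1, `CN1CC[C@@H]2CC[C@H](OCc3ccccc3)C[C@@H]21`, an assay on HEK293 cells for antagonist activity at Neuronal acetylcholine receptor; alpha3/beta4 (Rattus norvegicus), read by FLIPR, using a membrane potential dye; a lower number here means a stronger inhibitor, a higher number a weaker inhibitor: > 300000 nM
compound 2, `CO[C@H]1CC=C2CCN(C)[C@H]2C1`, this assay: > 300000 nM

The reading for compound 1 in this assay, > 300000 nM, is a limit of the assay and not a number. Compound 2 likewise gives > 300000 nM in this assay, which is a limit and not a measured number. Compound 2 therefore stands at the limit itself, since (the limit of > 300000 nM in this assay, at which 2 of the 2 values shown sit). Among the compounds with values here, no step between two measured compounds can be computed from such limits, so nothing measured tells how a small change on this core shifts the reading.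

Compound 3, `CCO[C@H]1CC=C2CCN(C)[C@H]2C1`, differs from compound 2 by methyl in place of hydrogen on a saturated chain carbon bound to an oxygen on a saturated carbon, that is, methoxy becomes ethoxy. A change of this size on a compound already at the limit is expected to give no step beyond the scatter in this assay. Compound 3 is thus expected to remain at the limit in this assay, an estimated 300000 nM, with a range from 100000 nM to 1000000 nM. The expected step from compound 2 to compound 3 is a number no higher from compound 2 to compound 3 (the limit leaves the size open).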

Compound 3, half-maximal inhibitory concentration: > 300000 nM
Compound 3 gave a limit, no number; the forecaster's own chance of this, stated with the estimate: 85%; the middle value lies on the limit itself.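

In this assay compound 3 gives > 300000 nM, which is a limit of the assay and not a number. Within the data shown here, compound 2 also sits at a limit, so no step from compound 2 to compound 3 can be read: the limit of > 300000 nM in this assay, at which 3 of the 3 values shown sit. The compounds shown leave open whether methoxy and ethoxy differ at all on this core, and how any change on it would shift the reading.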